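The source may report more compounds than this note shows. Statements on the series, on what has been measured and on what is new or still open speak of the compounds shown alone.

In a functional assay on DWD cells (Homo sapiens) for inhibition, read by sulforhodamine B assay (a higher number here means a weaker inhibitor of growth, a lower number a stronger inhibitor of growth), compound 1 `Cc1ccc2[nH]c(-c3ccc(-c4ccc(-c5ccc(N(C)C)cc5)cc4)cc3)nc2c1` gives 3230 nM, compound 2 `Oc1ccc(-c2ccc(-c3ccc(-c4nc5ccccc5[nH]4)cc3)cc2)cc1` gives 46300 nM and compound 3 `Cc1ccc2[nH]c(-c3ccc(-c4ccc(-c5ccc(C(F)(F)F)cc5)cc4)cc3)nc2c1` gives 38200 nM. Compound 3 thus lies within the scatter of compound 2, and the large step of a 12-fold higher number from compound 1 to compound 3 (1.07 log units; beyond the scatter) separates it from compound 1. Compound 4 `Cc1ccc2[nH]c(-c3ccc(-c4ccc(-c5ccc(O)cc5)cc4)cc3)nc2c1` has hydroxy in place of trifluoromethyl on an aromatic carbon, para to a large group: hydroxy in place of trifluoromethyl on an aromatic carbon. That large step shows that a change in this place can matter. However, compound 2 also bears hydroxy and gives 46300 nM, so no step beyond the scatter is expected in this assay. The expected step is a 1.4-fold lower number from compound 3 to compound 4 (0.13 log units; within the scatter). For compound 4 the estimated value is 28000 nM, with an expected range of 8000 nM to 70000 nM.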

Compound 4, concentration for 50% growth inhibition: 21200 nM
Estimate against measurement, compound 4: 1.3-fold (0.12 log units) above; the measured number falls inside the stated range.
By their numbers in this assay, from the lowest: compound 1; then compounds 4, 3 and 2 (each within the scatter of the next, the first and the last beyond it).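

In this assay, hydroxy in place of trifluoromethyl on this aromatic carbon stays within the scatter (a 1.8-fold lower number from compound 3 to compound 4 (0.26 log units; within the scatter)), so the two groups cannot be told apart here. Hydroxy in place of dimethylamino is a modest step (a 6.6-fold higher number from compound 1 to compound 4 (0.82 log units; beyond the scatter)), which leaves compound 1 apart from both compounds with the other groups. With hydroxy held constant, methyl in place of hydrogen on an aromatic carbon of the core also counts (a 2.2-fold lower number from compound 2 to compound 4 (0.34 log units; beyond the scatter)).

On these data alone, whether a primary amine or a carboxylic acid at this position would match dimethylamino remains open. Nothing shown here accounts for these differences.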